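The source may report more compounds than this note shows. Statements on the series, on what has been measured and on what is new or still open speak of the compounds shown alone.

Compound 1 `CC1(C)CCc2cc(C(=O)/C=C/c3ccc(OCc4cn(-c5ccc(Cl)cc5)nn4)cc3)c(O)cc2O1`: 92100 nM
Compound 2 `CC1(C)CCc2c(ccc(C(=O)/C=C/c3ccc(OCc4cn(-c5ccc(Br)cc5)nn4)cc3)c2O)O1`: 117000 nM

Both compounds were tested in a functional assay on IMR-32 cells (Homo sapiens) for antiproliferative activity, read by MTT assay; on this read-out lower numbers stand for stronger inhibition and higher numbers for weaker inhibition. Compound 1 stands within the scatter of compound 2, so the two numbers set no order between them. Compound 3 `CC1(C)CCc2cc(C(=O)/C=C/c3ccc(OCc4cn(Cc5ccc([N+](=O)[O-])cc5)nn4)cc3)c(O)cc2O1` keeps the core of compound 1 and has 4-nitrobenzyl in place of 4-chlorophenyl on an aromatic nitrogen of a five-membered aromatic ring with 3 nitrogen (4-nitrobenzyl in place of 4-chlorophenyl on an aromatic nitrogen). Among the compounds with values here, no measured pair shows what this change does in this assay, so the expectation rests on compound 1 at 92100 nM alone. No step beyond the scatter is expected, and no direction can be favoured. The expected change is a 1.2-fold lower number from compound 1 to compound 3 (0.06 log units; within the scatter). For compound 3 the estimated value is 80000 nM. The expected range for compound 3 runs from 30000 nM to 180000 nM.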

Compound 3, half-maximal inhibitory concentration: 108000 nM
Beside the measured number, compound 3's estimate is 1.4-fold (0.13 log units) below it; measured number inside the range.
By their numbers in this assay, from the lowest: compounds 1, 3 and 2 (each within the scatter of the next).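

In this assay, the exchange of 4-chlorophenyl for 4-nitrobenzyl on an aromatic nitrogen gives a 1.2-fold higher number from compound 1 to compound 3 (0.07 log units; within the scatter), the first step read at this position. The entering group has 10 heavy atoms against 7 and brings 2 hydrogen-bond acceptors, yet this single swap leaves the number within the scatter, so in this comparison the position tolerates both groups without a separable difference. Nothing available explains this outcome or ties it to any property of either group.

A single step on a single core cannot show whether this position is insensitive in general or whether these two groups merely happen to give similar numbers. Going by these compounds, it remains open whether an amine, a carboxylic acid or a longer chain on this aromatic nitrogen would give a step beyond the scatter.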